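Nitro removal on a naphthyloxyacetyl hydrazone: cytotoxicity outlook

The source may hold more compounds than are shown below. What is called first, only, known or untested is meant among the compounds shown, and "the series" means these compounds.

Measured compounds:
compound 1 `O=C(COc1cccc2ccccc12)N/N=C/c1ccc(Cl)cc1`, 100 ug/mL
compound 2 `C/C(=N\NC(=O)COc1cccc2ccccc12)c1cccc([N+](=O)[O-])c1`, 20 ug/mL

Two hydrazones sharing the naphthyloxyacetyl core have been measured in an ADME assay on HEL cells (Homo sapiens) for cytotoxicity; on this read-out lower numbers stand for higher toxicity in this test and higher numbers for lower toxicity in this test. Compound 1 `O=C(COc1cccc2ccccc12)N/N=C/c1ccc(Cl)cc1` gives 100 ug/mL in this assay. Compound 2 `C/C(=N\NC(=O)COc1cccc2ccccc12)c1cccc([N+](=O)[O-])c1` gives 20 ug/mL, the lowest of the two numbers, and compound 1 sits at a higher number, a gap that lies beyond the usual scatter. Compound 3 `C/C(=N\NC(=O)COc1cccc2ccccc12)c1ccccc1` has not yet been measured. It differs from compound 2 in one place: hydrogen in place of nitro on an aromatic carbon. Among the compounds with values here, no step between measured compounds isolates this change, so the direction rests on what the two values show. Compound 2 gives the lowest number, and the expectation is that compound 3 moves toward the higher number of compound 1, with an expected step of a 3.0-fold higher number from compound 2 to compound 3 (0.48 log units; beyond the scatter). The estimate for compound 3 is 60 ug/mL, with a range from 20 ug/mL to 100 ug/mL.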

Compound 3, minimum cytotoxic concentration: 20 ug/mL
Beside the measured number, compound 3's estimate is 3.0-fold (0.48 log units) above it; the range from low to high includes it.
By their numbers in this assay, from the lowest: compounds 2 and 3 (each within the scatter of the next); then compound 1.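

Hydrogen in place of nitro is the first change in this series that can be read in one place, and in this assay it gives no change at the digits printed from compound 2 to compound 3 (within the scatter) on the shared core. At this position, then, the number seen for compound 2 does not depend on the nitro group, since compound 3 carries only hydrogen there and stands level with it. No measured evidence bears on why this swap leaves the read-out where it is.

As far as these compounds go, whether an amine or a carboxylic acid on the same aromatic carbon would separate from the 3-nitrophenyl and phenyl pair remains open. Also open, from the compounds shown here alone, is whether the same swap would read the same way on the hydrogen-bearing hydrazone carbon of compound 1, which lacks the methyl group of compound 2 and compound 3.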